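Thiophen-3-yl replaces pyridin-4-yl on an unmeasured parent

This account rests on a few compounds, and the source may have more. Where it says the series, first, only, none or still open, it means among the compounds named here.

Three compounds built on a shared core have so far been taken through a functional assay on DU-145 cells (Homo sapiens) for cytotoxicity, read by CCK-8 assay and cell counting, with a stated time of 2 days (on this read-out higher numbers stand for weaker inhibition and lower numbers for stronger inhibition), as a test of cytotoxicity. There compound 1 (`Oc1ccc(-c2cc(-c3cccnc3)nc(-c3cccc(Cl)c3)c2)cc1`), which carries the 4-hydroxyphenyl group, gives 22900 nM as its half-maximal inhibitory concentration. Compound 2 (`Oc1cccc(-c2cc(-c3ccsc3)nc(-c3cccc(Cl)c3)c2)c1`), which carries the thiophen-3-yl group, gives 3330 nM on the same read-out, the lower of the two values.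

Compound 3 (`Oc1ccc(-c2cc(-c3ccncc3)nc(-c3cccc(Cl)c3)c2)cc1`) has no place on this scale: its entry in this assay reads "not determined" (no result reported) and offers no number to start from. Compound 4 (`Oc1ccc(-c2cc(-c3ccsc3)nc(-c3cccc(Cl)c3)c2)cc1`) differs from compound 3 by a single change, thiophen-3-yl in place of pyridin-4-yl on an aromatic carbon. Without a value for compound 3, no size or direction can be expected for this step, so the expectation rests on the neighbours instead. Compound 2 at 3330 nM shares the entering group but differs in its hydroxyphenyl group, while compound 1 at 22900 nM shares the 4-hydroxyphenyl group. Compound 4 is thus expected to fall within or near that span, closer to compound 2. In this assay the expected value for compound 4 is 6000 nM with an estimated range from 1800 nM to 20000 nM as its half-maximal inhibitory concentration.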

Compound 4, half-maximal inhibitory concentration: 6220 nM
Compound 4: the middle estimate sits 1.0-fold (0.02 log units) below what was measured; the range from low to high includes it.
By their numbers in this assay, from the lowest: compounds 2 and 4 (each within the scatter of the next); then compound 1.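

Among the compounds shown here, compound 3 has no number, so the step from pyridin-4-yl to thiophen-3-yl cannot be read, but at this same place, on the aromatic carbon next to the ring nitrogen, this assay does show a related change: thiophen-3-yl in place of pyridin-3-yl gives a 3.7-fold lower number from compound 1 to compound 4 (0.57 log units; beyond the scatter) and is the only step here that clears the scatter. With thiophen-3-yl held constant, 4-hydroxyphenyl in place of 3-hydroxyphenyl gives a 1.9-fold higher number from compound 2 to compound 4 (0.27 log units; within the scatter), so the scatter does not separate these two hydroxyphenyl arrangements. Nothing presented here accounts for either step.

For the compounds shown here, it remains open where pyridin-4-yl itself would fall on this scale, and so whether it would behave like pyridin-3-yl, since the one step that can be read at this place starts from that other pyridine. On these data alone, it is also open whether the gain seen with thiophen-3-yl extends to another five-membered aromatic ring such as furan-3-yl, or how an open group such as an aminomethyl chain would fare at this carbon.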